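Removing the isobutyl side chain from compound 2

The source may hold more compounds than are shown below. What is called first, only, known or untested is meant among the compounds shown, and "the series" means these compounds.

Measured compounds:
- compound 1, `CC1(C)CCC(C)(C)c2cc(NC(=O)c3ccc(C(=O)OCCCOC(=O)c4ccc(OCc5c(-c6ccccc6)no[n+]5[O-])cc4)cc3)ccc21`: > 1000000 nM
- compound 2, `CC(C)C[C@H](NC(=O)c1ccc(C(=O)Nc2ccc3c(c2)C(C)(C)CCC3(C)C)cc1)C(=O)OCc1c(-c2ccccc2)no[n+]1[O-]`: 64000 nM
- compound 3, `CC1(C)CCC(C)(C)c2cc(NC(=O)c3ccc(C(=O)OCCOC(=O)c4ccc(OCc5c(-c6ccccc6)no[n+]5[O-])cc4)cc3)ccc21`: > 1000000 nM

Of the compounds shown here, three have been tested in a functional assay on K562 cells (Homo sapiens) for antiproliferative activity, read by MTT assay, with a stated time of 48 h; on this read-out higher numbers stand for weaker inhibition and lower numbers for stronger inhibition. Among the measured compounds shown here, compound 2 is the only one that gives a number, with 64000 nM. For compound 1 the read-out is a limit of the assay, > 1000000 nM, and not a number. For compound 3 the read-out is likewise a limit, > 1000000 nM. For the measured compounds named here, the two limits sit at the limit of > 1000000 nM in this assay, at which 2 of the 3 values shown sit, so compound 2 stands alone as the one compound with a measurable number.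

Compound 4, `CC1(C)CCC(C)(C)c2cc(NC(=O)c3ccc(C(=O)NCC(=O)OCc4c(-c5ccccc5)no[n+]4[O-])cc3)ccc21`, has not yet been measured. It differs from compound 2 by hydrogen in place of isobutyl on a saturated chain carbon bound to an amide-type nitrogen and a carbonyl carbon. Going by the values given here, no pair of measured compounds shows what this change does, so there is no step to lean on. Since compound 2 is already a weak inhibitor, the expectation is a modest loss or no change beyond the scatter in this assay. Compound 4 is therefore expected to give 110000 nM, with a range from 30000 nM to 500000 nM. The expected step of a 1.7-fold higher number from compound 2 to compound 4 (0.24 log units; within the scatter) is small, and a limit rather than a number is possible.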

Compound 4, half-maximal inhibitory concentration: 7120 nM
The estimate for compound 4 lay 15-fold (1.19 log units) above the measured number, and the stated range ends above it.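

In this assay, hydrogen in place of isobutyl on this saturated chain carbon gives a 9.0-fold lower number from compound 2 to compound 4 (0.95 log units; beyond the scatter) and provides the first measured change at any place among these compounds. The isobutyl side chain is therefore not required for the activity of compound 2, and at this position the compound carrying only hydrogen gives the lower number, which here means stronger inhibition. This rests on a single pair, and nothing measured here explains why removing the isobutyl group has this effect.

On these data alone, it remains open whether a methyl group, an amine or a carboxylic acid on this carbon would give a lower or a higher number than hydrogen. As far as these compounds go, it is also open whether removing an isobutyl group would have a similar effect in compounds with a different linker.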